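Adding a Third Methoxy Group to Compound 3

A few compounds are considered here, and "the series" means these few. Any claim that something is new, unique, unknown or untested is made for them only; others in the source may bear on it.

The measured compounds, all tested in a functional assay for inhibition, with a stated time of 30 min, tested at 1 mM; a higher number here means more inhibition at the concentration tested (going by the name of the read-out), a lower number less inhibition:
Compound 1, `COc1ccc(/C(Cl)=C/C=C(\C#N)C(=O)c2c[nH]c3ccc(Br)cc23)cc1`, gives 15.6%.
Compound 2, `COc1ccc(/C(Cl)=C/C=C(\C#N)C(=O)c2c[nH]c3ccc(Br)cc23)cc1OC`, gives 11.8%.
Compound 3, `COc1ccc(/C(Cl)=C/C=C(\C#N)C(=O)c2c(C)[nH]c3ccccc23)cc1OC`, gives 22.4%.

Compound 2 differs from compound 1 by one change, (methoxy in place of hydrogen on an aromatic carbon), and in this assay this produced a number 3.8 percentage points lower from compound 1 to compound 2 (within the scatter). Compound 3 carries a different core; how its core differs from that of compound 1 is not broken down here, and its number sits close to that of compound 1.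

Compound 4, `COc1cc(/C(Cl)=C/C=C(\C#N)C(=O)c2c(C)[nH]c3ccccc23)cc(OC)c1OC`, has not been measured. It differs from compound 3 by methoxy in place of hydrogen on an aromatic carbon. This is the same kind of change as that from compound 1 to compound 2, though the surroundings are not identical: in compound 4 the entering group is also meta to a methoxy group, which was not the case for compound 2.

Given that the earlier step was small, the expected step in this assay is also small, a number 3.4 percentage points lower from compound 3 to compound 4 (within the scatter), resting on a number 3.8 percentage points lower from compound 1 to compound 2 (within the scatter). Compound 4 is therefore estimated at 19%, within 8% to 32%.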

Compound 4, a percentage reported as inhibition, at one concentration (the size of the read-out at that concentration, not a potency): 14.5%
Compound 4: middle estimate off by 4.5 percentage points, on the high side; low and high end bracket the measured number.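

In this assay the swap of hydrogen for methoxy on the ring of compound 3 gives a number 7.9 percentage points lower from compound 3 to compound 4 (within the scatter) and, set beside the same swap on the other core, it gives a matching picture: the same change on two cores in this assay, a number 3.8 percentage points lower (within the scatter) from compound 1 to compound 2 and a number 7.9 percentage points lower (within the scatter) from compound 3 to compound 4, 4.1 percentage points apart, within the scatter of two such steps.

So in these two pairs the change carries from one core to the other without a measurable difference, even though in compound 4 the entering methoxy is also meta to a methoxy group. What this does not show is that methoxy truly lowers the inhibition, since each step on its own stays within the scatter, and two pairs tested at a single concentration say nothing about potency.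

The compounds shown leave open whether a different group at this place, such as a hydroxyl, an amine or a longer chain like ethoxy, would shift the number beyond the scatter. They also leave open whether the same swap would behave alike on further cores.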